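Series notes: from compound 3 to compound 4

The source may hold more compounds than are shown below. What is called first, only, known or untested is meant among the compounds shown, and "the series" means these compounds.

Values in a functional assay on SW-620 cells (Homo sapiens) for cytotoxicity, read by MTT assay, with a stated time of 72 h (on this read-out higher numbers stand for weaker inhibition and lower numbers for stronger inhibition), follow.
Compound 1 `COc1cccc(/C=C2\CCC/C(=C\c3ccc(O)cc3)C2=O)c1OC` gives > 20000 nM as a limit.
Compound 2 `COc1ccc(/C=C2\CCC/C(=C\c3cccc(OC)c3OC)C2=O)c(OC)c1` gives > 20000 nM as a limit.
Compound 3 `COc1ccc(/C=C2\CCC/C(=C\c3cccc(Br)c3)C2=O)cc1OC` gives 4200 nM as a number.

For the measured compounds named here, compound 3 at 4200 nM holds the only number in the set, so no measured step is available. Compound 4 `COc1ccc(/C=C2\CCC/C(=C\c3ccc(O)cc3)C2=O)cc1OC` carries 4-hydroxyphenyl in place of 3-bromophenyl on a double-bonded chain carbon bound to a double-bonded ring carbon. Compound 1 also carries 4-hydroxyphenyl and gives only the limit > 20000 nM. Compound 2 goes against any link to that group, as it lacks it and also gives a limit. The expected change is weaker inhibition in this assay beyond the scatter, estimated as a 2.4-fold higher number from compound 3 to compound 4 (0.38 log units; beyond the scatter). For compound 4 the estimated value is 10000 nM, with an expected range from 3500 nM to 28000 nM.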

Compound 4, half-maximal inhibitory concentration: 7700 nM
Beside the measured number, compound 4's estimate is 1.3-fold (0.11 log units) above it; the measured number falls inside the stated range.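

In this assay the change from 3-bromophenyl to 4-hydroxyphenyl on a double-bonded chain carbon bound to a double-bonded ring carbon gives a 1.8-fold higher number from compound 3 to compound 4 (0.26 log units; within the scatter), so this step does not separate the two groups. Compound 4 shows that 4-hydroxyphenyl can occur in a compound with a measured number, which compound 1 did not show. Compound 1, with the same group, gives > 20000 nM as a limit.

From the compounds shown here alone, whether an amine or a carboxylic acid at this position would give a step beyond the scatter remains open. Steps involving compound 1 or compound 2 cannot be read: the limit of > 20000 nM in this assay, at which 2 of the 4 values shown sit.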